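A few compounds are considered here, and "the series" means these few. Any claim that something is new, unique, unknown or untested is made for them only; others in the source may bear on it.

Working notes on the series.

Compound 1 `CN(C(=O)CCc1ccccc1)c1ccc2[nH]c(-c3n[nH]c4ccccc34)cc2n1` is the reference point. Within the data shown here, in a functional assay on SMMC-7721 cells (Homo sapiens) for antiproliferative activity, read by MTT assay, with a stated time of 72 h (on this read-out lower numbers stand for stronger inhibition and higher numbers for weaker inhibition), compound 1 gives 20900 nM, the only numerical value in the set so far, and it stands as a weak inhibitor. Compound 2 `CN(C(=O)c1ccccc1)c1ccc2[nH]c(-c3n[nH]c4cc(C#N)ccc34)cc2n1` reaches only a limit. In this assay, among the measured compounds shown here, compound 2 gives > 50000 nM, which is a limit of the assay and not a number; this is the only comparison available (the limit of > 50000 nM in this assay, at which 1 of the 2 values shown sits). For the measured compounds named here, since no pair of measured compounds differs in a single place, no measured step exists to lean on.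

Compound 3 `Cc1ccc(S(=O)(=O)N(C)c2ccc3[nH]c(-c4n[nH]c5ccccc45)cc3n2)cc1` is the next analogue. Relative to compound 1 it carries (4-methylphenyl)sulfonyl in place of phenethylcarbonyl on a nitrogen on an aromatic ring. The amide that carried compound 1 to its value is replaced, and the series gives no clue to how a sulfonyl group at this nitrogen behaves. The expected step from compound 1 to compound 3 a 1.2-fold higher number from compound 1 to compound 3 (0.08 log units; within the scatter) is taken as small, with no direction asserted beyond the usual scatter, though a drift toward weaker inhibition would not surprise. For compound 3 the estimate in this assay is 25000 nM, within a range of 8000 nM to 80000 nM.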

Compound 3, half-maximal inhibitory concentration: 16300 nM
Compound 3: middle estimate off by 1.5-fold (0.19 log units), on the high side; the range from low to high includes it.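

Among these compounds, the exchange of phenethylcarbonyl for (4-methylphenyl)sulfonyl on a nitrogen on an aromatic ring gives a 1.3-fold lower number from compound 1 to compound 3 (0.11 log units; within the scatter) in this assay and is the first single-place step measured. This position therefore accepts a sulfonyl link in place of a carbonyl link with no step beyond the scatter, so the carbonyl of compound 1 is not needed to hold the number at this level, and compound 3 also remains a weak inhibitor on this read-out. Nothing among the data shown bears on why this step is small.

Going by these compounds, both groups compared here carry a six-membered aromatic ring of carbon only, so it remains open whether a group without that ring at this nitrogen, such as an amine, a carboxylic acid or a short alkyl chain, would move the number beyond the scatter. On these data alone, it also remains open whether a methyl group on the ring of the (4-methylphenyl)sulfonyl group matters at all, or whether the unsubstituted phenylsulfonyl or a chloro analogue would read the same in this assay on the shared core.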